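Moving the Piperidine Attachment from Compound 3 to Compound 4

The compounds below may be only part of what the source reports. "The series", "measured", "known", "first", "only" and "open" are said of these compounds alone.

Measured in an ADME assay on microsomes from liver (Rattus norvegicus) for metabolic stability, read by LC-MS, with a stated time of 10 min, tested at 0.5 uM; on this read-out higher numbers stand for a more stable compound and lower numbers for a less stable compound:
- compound 1 `c1ccc2c(c1)CN[C@@H](CN(CC1CCNCC1)[C@H]1CCCc3cccnc31)C2`: 65%
- compound 2 `c1ccc2c(c1)CN[C@@H](CN(CCCN1CCNCC1)[C@H]1CCCc3cccnc31)C2`: 100%
- compound 3 `c1ccc2c(c1)CN[C@@H](CN(CC[C@@H]1CCCNC1)[C@H]1CCCc3cccnc31)C2`: 28%

Compound 3 stands lowest of the three, as a number 37 percentage points lower from compound 1 to compound 3 (beyond the scatter) and a number 72 percentage points lower from compound 2 to compound 3 (beyond the scatter) show. Compound 4 `c1ccc2c(c1)CN[C@@H](CN(CCC1CCNCC1)[C@H]1CCCc3cccnc31)C2` differs from it by piperidin-4-yl in place of piperidin-3-yl on a saturated chain carbon, two bonds along the chain from an amine nitrogen. Among the compounds with values here, no measured step isolates this change. The closest is the large a number 37 percentage points lower from compound 1 to compound 3 (beyond the scatter), which joins the same ring change to a longer chain, while a number 35 percentage points higher from compound 1 to compound 2 (beyond the scatter) bears on it less directly. A partial recovery towards compound 1 at 65% is therefore expected, a moderate rise beyond the scatter. The expected step is a number 17 percentage points higher from compound 3 to compound 4 (beyond the scatter). For compound 4 the estimated value is 45%, with an expected range of 25% to 68%.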

Compound 4, percent of the compound remaining: 17%
Beside the measured number, compound 4's estimate is 28 percentage points above it, and the stated range ends above it.
By their numbers in this assay, from the lowest: compound 4; then compound 3; then compound 1; then compound 2.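

In this assay the exchange of piperidin-3-yl for piperidin-4-yl gives a number 11 percentage points lower from compound 3 to compound 4 (beyond the scatter), so this ring change alone does not recover the number at this position. With the piperidin-4-yl ring held, the change to (piperidin-4-yl)methyl gives a number 48 percentage points lower from compound 1 to compound 4 (beyond the scatter) and so shows the chain step apart from any ring change. The (piperazin-1-yl)methyl group stays far ahead, with a number 83 percentage points lower from compound 2 to compound 4 (beyond the scatter) on replacing it by piperidin-4-yl. Going by these compounds, whether a longer chain on the piperidin-4-yl ring, or a morpholine in its place, would follow this order stays open. No evidence at hand explains these steps.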